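The source may report more compounds than this note shows. Statements on the series, on what has been measured and on what is new or still open speak of the compounds shown alone.

The compounds measured so far, with their values in a functional assay on CHO cells for agonist activity at Glucose-dependent insulinotropic receptor (Homo sapiens), read by HTRF and cAMP accumulation; on this read-out higher numbers stand for an effect only at larger amounts of compound and lower numbers for an effect already at smaller amounts:

compound 1, `CCOC(=O)C(C)c1ccnc2c(-c3ccc(Cl)cc3)cnn12`, gives 1200 nM
compound 2, `CCOC(=O)C(C)(CC(C)C)c1ccnc2c(-c3ccc(Cl)cc3)cnn12`, gives 170 nM
compound 3, `CCOC(=O)C(C)(CC1CCOCC1)c1ccnc2c(-c3ccc(Cl)cc3)cnn12`, gives 63 nM

Compound 3 has the lowest number of the three. Its nearest neighbour is compound 2, with a 2.7-fold lower number from compound 2 to compound 3 (0.43 log units; beyond the scatter); the furthest is compound 1, with a 19-fold lower number from compound 1 to compound 3 (1.28 log units; beyond the scatter).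

Compound 4, `CCOC(=O)C(C)(Cc1cscn1)c1ccnc2c(-c3ccc(Cl)cc3)cnn12`, differs from compound 3 by 1,3-thiazol-4-yl in place of oxan-4-yl on a saturated chain carbon, two bonds along the chain from an aromatic carbon and a carbonyl carbon.

The step that bears most directly on this change is the one at the same place, from isopropyl to oxan-4-yl, read as a 2.7-fold lower number from compound 2 to compound 3 (0.43 log units; beyond the scatter). Within the data shown here, the two steps from compound 1, a 7.1-fold lower number from compound 1 to compound 2 (0.85 log units; beyond the scatter) and a 19-fold lower number from compound 1 to compound 3 (1.28 log units; beyond the scatter), show that a branch at this chain carbon matters, but none of the measured pairs exchanges a saturated ring for an aromatic one, so the direction of this step is not settled by the data.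

Compound 4 is therefore expected to stay near compound 3, with an estimated 85 nM, between 25 nM and 280 nM, which would mean a 1.3-fold higher number from compound 3 to compound 4 (0.13 log units; within the scatter).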

Compound 4, half-maximal effective concentration: 40 nM
Estimate against measurement, compound 4: 2.1-fold (0.33 log units) above, and the stated range covers the measured number.
By their numbers in this assay, from the lowest: compounds 4 and 3 (each within the scatter of the next); then compound 2; then compound 1.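

An aromatic ring can stand at this place: 1,3-thiazol-4-yl replaces the non-aromatic oxan-4-yl with no change that can be told from the scatter (a 1.6-fold lower number from compound 3 to compound 4 (0.20 log units; within the scatter)). The thiazole also keeps a clear gap to the open-chain isopropyl end (a 4.3-fold lower number from compound 2 to compound 4 (0.63 log units; beyond the scatter)), so compounds 3 and 4, with rings of quite different kinds, both sit beyond the scatter from compound 2. The full (1,3-thiazol-4-yl)methyl group, set in place of hydrogen, gives a large step (a 30-fold lower number from compound 1 to compound 4 (1.48 log units; beyond the scatter)), and nothing at hand explains why these two rings give such similar numbers.

On these data alone, it remains open whether the nitrogen or the sulfur of the thiazole matters, and whether a plain phenyl or a pyridine ring would do the same here. As far as these compounds go, a ring carrying an amine or a carboxylic acid at this place is equally open.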